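From Compound 1 to Compound 3: Nitro Replaced by Hydrogen

A few compounds are considered here, and "the series" means these few. Any claim that something is new, unique, unknown or untested is made for them only; others in the source may bear on it.

Within the data shown here, in an ADME assay on MT4 cells (Homo sapiens) for cytotoxicity, read by MTT assay, with a stated time of 96 h (a higher number here means that more compound is tolerated, a lower number that less compound is tolerated), only two compounds have numbers so far. Compound 1 (`CN(C)CCCN(/N=N/c1ccc([N+](=O)[O-])cc1)c1ccccc1`) gives 20000 nM as the lowest of the two numbers, so less of it is tolerated. Compound 2 (`Fc1ccc(F)c(/N=N/Nc2ccccc2)c1`) gives 100000 nM as the higher number, and the gap between the two lies beyond the usual scatter.

The next compound to be read is compound 3 (`CN(C)CCCN(/N=N/c1ccccc1)c1ccccc1`). It has hydrogen in place of nitro on an aromatic carbon, para to a large group (hydrogen in place of nitro on an aromatic carbon). Among the measured compounds shown here, no pair of measured compounds shows this change, so the size of the step cannot be read from the data and remains a judgement. A small upward step in this assay is expected, one that may not clear the scatter. The estimated step is a 1.8-fold higher number from compound 1 to compound 3 (0.24 log units; within the scatter) and it could turn out larger or smaller. For compound 3 the expected value is 35000 nM with an estimated range from 12000 nM to 100000 nM at this stage.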

Compound 3, half-maximal cytotoxic concentration: 33000 nM
Estimate against measurement, compound 3: 1.1-fold (0.03 log units) above, and the stated range covers the measured number.
By their numbers in this assay, from the lowest: compounds 1 and 3 (each within the scatter of the next); then compound 2.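

In this assay, among these compounds, hydrogen in place of nitro on an aromatic carbon, para to a large group, gives a 1.7-fold higher number from compound 1 to compound 3 (0.22 log units; within the scatter), the first step between compounds that differ in one place. At this position, then, the loss of nitro with its 3 heavy atoms and 2 hydrogen-bond acceptors gives no difference that can be told from the usual scatter, so this pair does not separate the two compounds on tolerated concentration. No measurement of any property of these compounds bears on this step, and the step stands without an explanation.

Going by these compounds, whether another group at this position, such as an amine, a methoxy group or a carboxylic acid, would move the number beyond the scatter remains open, as does whether the same replacement would give a similar step on a different core. Among the compounds shown here, compound 2 differs from compound 1 and compound 3 in more than one place, so no step to it can be read, and the single pair here supports no general pattern for the series.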